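This account rests on a few compounds, and the source may have more. Where it says the series, first, only, none or still open, it means among the compounds named here.

Compound 1 `N=C(N)NS(=O)(=O)c1ccc(N/C(S)=N\c2ccnc3cc(C(F)(F)F)ccc23)cc1` gives 24300 nM in a functional assay on HT-1080 cells (Homo sapiens) for antiproliferative activity, read by sulforhodamine B assay, with a stated time of 48 h; a higher number here means a weaker inhibitor, a lower number a stronger inhibitor.
Compound 2 `Cc1noc(NS(=O)(=O)c2ccc(N/C(S)=N\c3ccnc4cc(C(F)(F)F)ccc34)cc2)c1C` gives 27700 nM in this assay.
Compound 3 `O=S(=O)(Nc1nccs1)c1ccc(N/C(S)=N\c2ccnc3cc(C(F)(F)F)ccc23)cc1` gives 27300 nM in this assay.

Among these three numbers compound 3 stands second highest, with compound 2 nearest and compound 1 furthest, and both gaps lie within the scatter. Compound 4 `O=S(=O)(Nc1ccccn1)c1ccc(N/C(S)=N\c2ccnc3cc(C(F)(F)F)ccc23)cc1` differs from compound 3 by pyridin-2-yl in place of 1,3-thiazol-2-yl on a sulfonamide nitrogen. Among the compounds with values here, three measured steps bear on this, since each changes the group on the same sulfonamide nitrogen: a 1.1-fold higher number from compound 1 to compound 2 (0.06 log units; within the scatter), a 1.1-fold higher number from compound 1 to compound 3 (0.05 log units; within the scatter) and a 1.0-fold lower number from compound 2 to compound 3 (0.01 log units; within the scatter), all within the scatter. Three different groups at this position have therefore left this assay essentially unchanged, and a fourth is expected to do the same, so the expected step is a 1.0-fold lower number from compound 3 to compound 4 (0.00 log units; within the scatter), no change beyond the scatter. Compound 4 is estimated at 27000 nM, within a range of 12000 nM to 60000 nM.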

Compound 4, half-maximal inhibitory concentration: 28000 nM
For compound 4 the middle estimate is 1.0-fold (0.02 log units) below the measured one, and the stated range covers the measured number.
By their numbers in this assay, from the lowest: compounds 1, 3, 2 and 4 (each within the scatter of the next).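

In this assay the pyridin-2-yl ring on the sulfonamide nitrogen gives no separation from the other groups: a 1.0-fold higher number from compound 3 to compound 4 (0.01 log units; within the scatter) and a 1.0-fold higher number from compound 2 to compound 4 (0.00 log units; within the scatter) and a 1.2-fold higher number from compound 1 to compound 4 (0.06 log units; within the scatter) all lie within the scatter. A six-membered aromatic ring in place of a five-membered one, without the ring sulfur, therefore leaves the number where the earlier groups had it. Nothing measured here accounts for this insensitivity.

Still open, going by these compounds, is whether a simple methyl or a carboxylic acid on this nitrogen would shift the number. So is whether replacing the trifluoromethyl on the shared core with a chlorine would do so.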